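The compounds below may be only part of what the source reports. "The series", "measured", "known", "first", "only" and "open" are said of these compounds alone.

Compound 3, whose structure is `CN1CCN(c2ccc(Nc3ncc4nc(Nc5ccc(F)cc5)n([C@H]5CCNC5)c4n3)cc2)CC1`, gives 1220 nM in a functional assay on HCC827 cells (Homo sapiens) for antiproliferative activity, read by MTT assay, with a stated time of 72 h; a higher number here means a weaker inhibitor, a lower number a stronger inhibitor. Among the three measured compounds it carries the highest number: the nearest is compound 2, `CN1CCN(c2ccc(Nc3ncc4nc(Nc5ccccc5)n([C@H]5CCNC5)c4n3)cc2)CC1`, with 530 nM, and the furthest is compound 1, `CN1CCN(c2ccc(Nc3ncc4nc(Nc5ccccc5)n([C@H]5CCN(C(=O)OC(C)(C)C)C5)c4n3)cc2)CC1`, with 110 nM. Compound 4, `CNC(=O)CN1CC[C@H](n2c(Nc3ccc(F)cc3)nc3cnc(Nc4ccc(N5CCN(C)CC5)cc4)nc32)C1`, has not yet been measured. Relative to compound 3 it carries (methylcarbamoyl)methyl in place of hydrogen on an amine nitrogen in a ring, that is, (methylcarbamoyl)methyl in place of hydrogen on an amine nitrogen in a ring, the five-membered non-aromatic ring that bears the large group.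

One measured step speaks to this change. Going a 4.8-fold higher number from compound 1 to compound 2 (0.68 log units; beyond the scatter), a group on that same ring nitrogen was removed and the number rose. Compound 4 restores a substituent there, though of a different kind, so the reverse direction, a lower number, is the expectation. The fluoro group itself is present in both compound 3 and compound 4. The step of a 2.3-fold higher number from compound 2 to compound 3 (0.36 log units; beyond the scatter) concerns that group and offers no guidance on its own. A modest lowering is therefore expected, of a size like a 2.4-fold lower number from compound 3 to compound 4 (0.39 log units; beyond the scatter). For compound 4 the estimated value in this assay is 500 nM, with a range from 150 nM to 1500 nM.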

Compound 4, half-maximal inhibitory concentration: 1520 nM
Compound 4: middle estimate off by 3.0-fold (0.48 log units), on the low side; measured number outside the range, above it.
By their numbers in this assay, from the lowest: compound 1; then compound 2; then compounds 3 and 4 (each within the scatter of the next).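

In this assay, (methylcarbamoyl)methyl in place of hydrogen on the amine nitrogen of the five-membered ring gave a 1.2-fold higher number from compound 3 to compound 4 (0.10 log units; within the scatter), so the two numbers cannot be told apart. The earlier step, a 4.8-fold higher number from compound 1 to compound 2 (0.68 log units; beyond the scatter), had tied a lower number to tert-butoxycarbonyl on that nitrogen, though in compounds without the fluoro group; the new result shows that a substituent there does not by itself bring a lower number, and that what holds for tert-butoxycarbonyl does not carry over to every group at this position. No measurement in hand accounts for this difference between the two groups.

On these data alone, it remains open whether tert-butoxycarbonyl would give a lower number alongside the fluoro group as well, which would separate its contribution from the background in which it was seen. As far as these compounds go, it is also open how the number would respond on this nitrogen to a simple methyl, an acetyl, a longer alkyl chain or a carboxylic acid, and so whether any pattern runs through the groups at this position.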